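From quinoline to benzodioxin on the amide carbonyl

The source may hold more compounds than are shown below. What is called first, only, known or untested is meant among the compounds shown, and "the series" means these compounds.

Of the compounds shown here, two built on one shared core have been measured in a functional assay on the whole organism (blood) with Rattus norvegicus as the target, with stated times of 24 h and 1 h, at a dose of 5 mg/kg by the intraperitoneal route; on this read-out lower numbers stand for a weaker effect and higher numbers for a stronger effect at the one dose given. Compound 1 `O=C(NC1CCCCC1)NS(=O)(=O)N1CCC(CCNC(=O)C(F)(F)F)CC1` carries a trifluoromethyl on the carbonyl carbon of its side-chain amide, and in this assay compound 1 gives 13%. Compound 2 `O=C(NC1CCCCC1)NS(=O)(=O)N1CCC(CCNC(=O)c2cccc3cccnc23)CC1` carries quinolin-8-yl in that place, and in this assay compound 2 gives 37%. Among the compounds with values here, compound 2 thus stands highest of the two numbers, with compound 1 as its only neighbour, and the single measured step is a number 24 percentage points higher from compound 1 to compound 2 (beyond the scatter).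

Compound 3 `O=C(NC1CCCCC1)NS(=O)(=O)N1CCC(CCNC(=O)c2cccc3c2OCCO3)CC1` has not been measured. Its difference from compound 2 is 2,3-dihydro-1,4-benzodioxin-5-yl in place of quinolin-8-yl on a carbonyl carbon. Within the data shown here, no measured step exchanges one ring-bearing group for another on that carbonyl carbon; the step from compound 1 to compound 2 only shows what happens when trifluoromethyl gives way to a group with aromatic rings. Because that step is a number 24 percentage points higher from compound 1 to compound 2 (beyond the scatter) and the incoming group also holds a six-membered aromatic ring of carbon only, compound 3 is expected to land near compound 2. The expected step is a number 7 percentage points lower from compound 2 to compound 3 (within the scatter), within the scatter. The estimate for compound 3 is 30%, with a range from 12% to 50%.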

Compound 3, a percentage reported as activity, at one dose (the size of the read-out at that dose, not a potency): 34%
For compound 3 the middle estimate is 4 percentage points below the measured one; the range from low to high includes it.
By their numbers in this assay, from the lowest: compound 1; then compounds 3 and 2 (each within the scatter of the next).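

In this assay the carbonyl carbon of the side-chain amide now has a step from one ring-bearing group to another, and a number 3 percentage points lower from compound 2 to compound 3 (within the scatter) leaves quinolin-8-yl and 2,3-dihydro-1,4-benzodioxin-5-yl indistinguishable on this read-out. The exchange is not a small one on paper: at the same count of 10 heavy atoms, an aromatic ring holding one nitrogen gives way to a non-aromatic ring holding two oxygens, and the read-out still stays within its usual scatter. The rise over trifluoromethyl also no longer rests on compound 2 alone, since a number 21 percentage points higher from compound 1 to compound 3 (beyond the scatter) is a second step of this kind beyond the scatter, though two groups are too few to make a general rule.

Going by these compounds, whether a plain phenyl ring, a saturated cyclohexyl ring or a ring carrying an amine or a carboxylic acid on that carbonyl carbon would read like these two groups remains open. No measured evidence is available on what lies behind the similar numbers of compound 2 and compound 3.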